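Halogen swap on the anilino ring: bromo to chloro

This account rests on a few compounds, and the source may have more. Where it says the series, first, only, none or still open, it means among the compounds named here.

Going by the values given here, compound 1 `O=S(=O)(Nc1ccncc1Nc1cccc(Br)c1)C(F)(F)F` is the only member of the series with a number in a functional assay on the whole organism (strain Wistar) with Rattus norvegicus as the target, with stated times of 30 min and 4 h, at a dose of 5 mg/kg by the intraperitoneal route; a higher number here means a stronger effect of the compound at the dose given, a lower number a weaker effect; there compound 1 gives 27.1%. Compound 2 `Cc1ccc(Nc2cnccc2NS(=O)(=O)C(F)(F)F)cc1Br` is reported in this assay as "not active" (no number reported), with no number attached. Compound 3 `O=S(=O)(Nc1ccncc1Nc1cccc(Cl)c1)C(F)(F)F` differs from compound 1 by chloro in place of bromo on an aromatic carbon. Among the compounds with values here, no step between measured compounds covers this change, so the expected step is small, within the scatter or slightly downward: a number 5.1 percentage points lower from compound 1 to compound 3 (within the scatter). Compound 3 is accordingly estimated at about 22% in this assay, with a range from 5% to 40%.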

Compound 3, a percentage reported as activity, at one dose (the size of the read-out at that dose, not a potency): "not active" (no number reported)
For compound 3 the study gives words and no number, and the estimate cannot be compared.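

Going by these compounds alone, compound 3 has words and no number in this assay, so no new step from compound 1 can be read. As far as these compounds go, what the 3-bromophenyl to 3-chlorophenyl change does to the read-out stays open. No measurement shown offers an explanation.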